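The compounds below may be only part of what the source reports. "The series", "measured", "known", "first", "only" and "open" are said of these compounds alone.

Compound 1 `CCCCCCC(CCO)n1c(Br)nc2c(Cl)ncnc21`: 16100 nM
Compound 2 `CCCCCCCCC(CCO)n1c(Br)nc2c(Cl)ncnc21`: 22400 nM

Both values come from a functional assay on HCT-116 cells (Homo sapiens) for antiproliferative activity, read by MTT assay, with a stated time of 48 h; on this read-out higher numbers stand for weaker inhibition and lower numbers for stronger inhibition. Among the compounds with values here, compound 2, at 22400 nM, stands within the scatter of compound 1, the only other compound measured. Within the data shown here, the single measured step, a 1.4-fold higher number from compound 1 to compound 2 (0.14 log units; within the scatter), placed ethyl in place of hydrogen on a saturated chain carbon, seven bonds along the chain from an aromatic nitrogen. Compound 3 `CCCCCCCCCC(CCO)n1c(Br)nc2c(Cl)ncnc21` extends the same chain, with methyl in place of hydrogen on a saturated chain carbon, nine bonds along the chain from an aromatic nitrogen. With only a 1.4-fold higher number from compound 1 to compound 2 (0.14 log units; within the scatter) to go on, and that step within the scatter, no step beyond the scatter is expected in this assay, and no firm direction can be drawn from it. The estimate is a 1.1-fold higher number from compound 2 to compound 3 (0.03 log units; within the scatter). Compound 3 is expected at 24000 nM, with an estimated range of 12000 nM to 50000 nM.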

Compound 3, half-maximal inhibitory concentration: 26900 nM
Beside the measured number, compound 3's estimate is 1.1-fold (0.05 log units) below it; low and high end bracket the measured number.
By their numbers in this assay, from the lowest: compounds 1, 2 and 3 (each within the scatter of the next).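

In this assay, methyl in place of hydrogen on a saturated chain carbon, nine bonds along the chain from an aromatic nitrogen, gives a 1.2-fold higher number from compound 2 to compound 3 (0.08 log units; within the scatter), and the larger extension of the same chain gives a 1.7-fold higher number from compound 1 to compound 3 (0.22 log units; within the scatter). Both steps lie within the scatter, so even the full span from the shortest to the longest chain shown produces no step beyond it, which the single earlier step could not show. No measured evidence bears on these numbers or offers a reason for them.

The compounds shown leave open whether a still longer chain, or a much shorter one such as ethyl, would give a step beyond the scatter. They also leave open how a chain ending in an amine or a carboxylic acid would read in this assay.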